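The source may report more compounds than this note shows. Statements on the series, on what has been measured and on what is new or still open speak of the compounds shown alone.

Compound 3, `N=C(N)NCCC[C@H](NC(=O)CN(c1nc(Cl)nc2[nH]cnc12)C1CC1)C(=O)OCc1ccccc1`, gives 10.2% in a functional assay on the whole organism (Tail, strain ICR) with Mus musculus as the target, in the tail flick test, with a stated time of 120 min, at a dose of 25 umol/kg by the oral route; a higher number here means a stronger effect of the compound at the dose given, a lower number a weaker effect. For the measured compounds named here, that is the lowest of the three numbers so far in hand. Compound 1, `O=C(CN(c1nc(Cl)nc2[nH]cnc12)C1CC1)N[C@@H](CO)C(=O)OCc1ccccc1`, gives 34.5% in this assay, and compound 2, `CC(C)[C@H](NC(=O)CN(c1nc(Cl)nc2[nH]cnc12)C1CC1)C(=O)OCc1ccccc1`, gives 27.3%. The step of a number 7.2 percentage points lower from compound 1 to compound 2 (within the scatter) lies within the scatter, whereas a number 24.3 percentage points lower from compound 1 to compound 3 (beyond the scatter) and a number 17.1 percentage points lower from compound 2 to compound 3 (beyond the scatter) both lie beyond it, and in both of these the change is the arrival of the group that compound 3 carries on its side chain, with the number falling each time.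

Compound 4, `CSCC[C@H](NC(=O)CN(c1nc(Cl)nc2[nH]cnc12)C1CC1)C(=O)OCc1ccccc1`, differs from compound 3 by a group of 2 heavy atoms (1 carbon, 1 sulfur; no ring) in place of a group of 5 heavy atoms (2 carbon, 3 nitrogen; no ring), on a saturated chain carbon, three bonds along the chain from an amide-type nitrogen and a carbonyl carbon. Going by the values given here, the group that leaves makes up most of what set compound 3 apart from compounds 1 and 2, and its arrival accompanied the two drops just described, so those two steps are the ones that bear on this change; no measured step shows the methylsulfanyl group itself. On this basis compound 4 is expected to move back up toward the region of compounds 1 and 2, a rise of a number 17.8 percentage points higher from compound 3 to compound 4 (beyond the scatter), since the drops to compound 3 were only modest. The estimate for compound 4 is 28%, with a range from 14% to 42%.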

Compound 4, a percentage reported as activity, at one dose (the size of the read-out at that dose, not a potency): 31.6%
Beside the measured number, compound 4's estimate is 3.6 percentage points below it; the range from low to high includes it.
By their numbers in this assay, from the lowest: compound 3; then compounds 2, 4 and 1 (each within the scatter of the next).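

For the compounds shown here, the step of a number 21.4 percentage points higher from compound 3 to compound 4 (beyond the scatter) in this assay shows directly what the earlier compounds showed only through changes of the whole side chain: on a saturated chain carbon, three bonds along the chain from an amide-type nitrogen and a carbonyl carbon, methylsulfanyl in place of the group carried by compound 3 goes with a clear rise. The other two steps, a number 4.3 percentage points higher from compound 2 to compound 4 (within the scatter) and a number 2.9 percentage points lower from compound 1 to compound 4 (within the scatter), show that 2-(methylsulfanyl)ethyl cannot be told apart from isopropyl, and that (methylsulfanyl)methyl cannot be told apart from hydroxy at its place, so among these four compounds only compound 3 stands apart, while compounds 1, 2 and 4 form one group. Nothing further in hand speaks to why the number moves in this way.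

Going by these compounds, whether a primary amine or a carboxylic acid at the end of this side chain would go with a number as low as that of compound 3, or a phenyl ring with one like that of compound 4, remains open. On these data alone, the read-out gives the size of the effect at one dose, so how these compounds compare in potency also remains open.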